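The compounds below may be only part of what the source reports. "The series", "measured", "known", "first", "only" and "open" are said of these compounds alone.

Compound 1 `Cc1nc(-c2ccccc2)c(C(=O)N2CCN(c3cccc(C(F)(F)F)c3)CC2)o1` and compound 2 `CCc1nc(-c2ccccc2F)c(C(=O)N2CCN(c3cccc(Cl)c3)CC2)o1` share a core and were both tested in a functional assay on HL-60 cells (Homo sapiens) for inhibition, read by MTT assay, with a stated time of 72 h; on this read-out higher numbers stand for weaker inhibition and lower numbers for stronger inhibition. In this assay compound 1 gives 153 nM, and compound 2 gives 139 nM, so the two values lie within the usual scatter of each other and neither can be called stronger. A third compound, compound 3 `O=C(c1oc(C(F)(F)F)nc1-c1ccc(F)cc1)N1CCN(c2cccc(Cl)c2)CC1`, carries a trifluoromethyl on the shared core instead of a methyl or ethyl; in this assay compound 3 is reported as "not active" (no number reported), with no number given.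

The step under consideration leads from compound 1 to compound 4 `Cc1ccc(C)c(N2CCN(C(=O)c3oc(C)nc3-c3ccccc3)CC2)c1`. Counted from the two structures, the change is 2,5-dimethylphenyl in place of 3-(trifluoromethyl)phenyl on an amine nitrogen in a ring. Among the compounds with values here, no measured pair shows this change, so its effect is unknown; the two aryl groups in compound 1 and compound 2 give values within the scatter of each other, which suggests that the aryl on the amine nitrogen in the ring tolerates variation, though 2,5-dimethylphenyl is a different kind of substitution.

Compound 4 is therefore expected to stay near compound 1, with at most a modest loss, and the step of a 2.0-fold higher number from compound 1 to compound 4 (0.29 log units; within the scatter) is the estimated size of that change. The estimate for compound 4 in this assay is 300 nM, with a range from 100 nM to 1200 nM.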

Compound 4, half-maximal inhibitory concentration: 31.3 nM
Compound 4: middle estimate off by 9.6-fold (0.98 log units), on the high side, outside the stated range (below it).
By their numbers in this assay, from the lowest: compound 4; then compounds 2 and 1 (each within the scatter of the next).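

In this assay, the step shows that the aryl group on the amine nitrogen in the ring can change the read-out by itself: 2,5-dimethylphenyl in place of 3-(trifluoromethyl)phenyl gives a 4.9-fold lower number from compound 1 to compound 4 (0.69 log units; beyond the scatter), with the rest of the structure unchanged. The earlier compounds shown here could not show this, as compound 1 and compound 2 differ in more than one place, so their closeness said nothing about this position alone. Nothing given here explains the lower number, which stands for stronger inhibition, so the change can be reported but not accounted for.

This single step does not separate the loss of trifluoromethyl from the arrival of the two methyl groups, and it does not show whether one methyl group alone, at either of the two places it holds in 2,5-dimethylphenyl, would give the same result. Also open, from the compounds shown here alone, is how an unsubstituted phenyl or a methoxyphenyl would read at this position, and whether the step would hold with ethyl in place of the methyl on the shared core.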